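The source may hold more compounds than are shown below. What is called first, only, known or untested is meant among the compounds shown, and "the series" means these compounds.

Within the data shown here, compound 3 `Cc1nn(-c2ccccc2C(F)(F)F)c2c1C(c1ccc(Oc3ccccc3)cc1)SC(C)C(=O)N2` is one of three compounds measured so far in an assay on isolated protein for agonist activity at Bile acid receptor (Homo sapiens), read by AlphaScreen, with a stated time of 30 min; on this read-out lower numbers stand for smaller maximal responses and higher numbers for larger maximal responses. In this assay compound 3 gives 50%, the second highest of the three numbers. Its nearest neighbour is compound 1 `Cc1ccccc1-n1nc(C)c2c1NC(=O)[C@H](C)S[C@@H]2c1ccc(-c2ccccc2)cc1`, which in this assay gives 24%, a number lower than that of compound 3 by an amount beyond the usual scatter. Furthest from it stands compound 2 `Cc1nn(-c2ccccc2C(C)C)c2c1[C@@H](c1ccc(Oc3ccccc3)cc1)S[C@@H](C)C(=O)N2`, which in this assay gives 174%, far higher than compound 3 and well beyond the scatter. Among the measured compounds shown here, compounds 1 and 2 each differ from compound 3 in more than one place, so no single step between measured compounds is available to guide an expectation.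

The next compound, compound 4 `Cc1nn(-c2ccccc2F)c2c1C(c1ccc(Oc3ccccc3)cc1)SC(C)C(=O)N2`, differs from compound 3 by a single change: fluoro in place of trifluoromethyl on an aromatic carbon. For the measured compounds named here, since no measured pair shows this change on its own, only a loose expectation is possible. A small move downward, or none beyond the scatter, is expected, so that compound 4 is estimated to lie close to compound 3, with the expected step from compound 3 to compound 4 amounting to a number 10 percentage points lower from compound 3 to compound 4 (within the scatter). In this assay compound 4 is therefore expected to give about 40%, with a plausible range from 15% to 90%.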

Compound 4, largest response reached (reported as efficacy), in percent of the reference or control that the assay uses: 72%
For compound 4 the middle estimate is 32 percentage points below the measured one; measured number inside the range.
By their numbers in this assay, from the lowest: compound 1; then compound 3; then compound 4; then compound 2.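

In this assay, among these compounds, replacing trifluoromethyl with fluoro on an aromatic carbon ortho to a large group gives a number 22 percentage points higher from compound 3 to compound 4 (beyond the scatter), the first reading of a single change. It shows that the response is sensitive to the group at this position, and that here the group with 1 heavy atom gives a larger maximal response than the one with 4 heavy atoms, although this single pair cannot establish a trend. No accompanying measurement offers a reason for this step.

The compounds shown leave open how a chloro group, a methoxy group or a nitrile on this same aromatic carbon would read in this assay, and so whether the response follows any ordering across groups at this position. They also leave open whether the same change would give a step of similar size and direction if the phenoxyphenyl group of compound 3 and compound 4 were replaced, or if each of the two were tested as a single stereoisomer.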